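The compounds below may be only part of what the source reports. "The series", "measured", "known", "first", "only" and "open" are said of these compounds alone.

Working notes on the series. Among the measured compounds shown here, compound 1 `CN1CCN(C(=O)c2cc(-c3ccc(Cl)cc3Cl)n[nH]2)CC1` is the weaker of the two compounds measured so far: in an assay on isolated protein for inhibition of alkaline phosphatase, tissue-nonspecific isozyme (Homo sapiens) (a lower number here means a stronger inhibitor, a higher number a weaker inhibitor), compound 1 gives 828 nM, whereas compound 2 `O=C(NCCO)c1cc(-c2cc(F)c(Cl)cc2Cl)n[nH]1` gives 100 nM in this assay, a gap well beyond the scatter, though compound 2 differs from compound 1 in more than one place. Compound 3 `O=C(NCCCCO)c1cc(-c2ccc(Cl)cc2Cl)n[nH]1` carries (4-hydroxybutyl)amino in place of 4-methylpiperazin-1-yl on a carbonyl carbon. No single-change comparison is available for this exchange. A moderate step toward stronger inhibition, a 3.3-fold lower number from compound 1 to compound 3 (0.52 log units; beyond the scatter), is expected for compound 3, guided by the value of compound 2 at 100 nM. The estimate for compound 3 in this assay is 250 nM, within a range of 80 nM to 800 nM.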

Compound 3, half-maximal inhibitory concentration: 35 nM
Estimate against measurement, compound 3: 7.1-fold (0.85 log units) above; the measured number lies below the stated range.
By their numbers in this assay, from the lowest: compound 3; then compound 2; then compound 1.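

Among the compounds shown here, on the carbonyl carbon of the shared core, (4-hydroxybutyl)amino in place of 4-methylpiperazin-1-yl gives a 24-fold lower number from compound 1 to compound 3 (1.37 log units; beyond the scatter) in this assay, the first single-change reading. The inhibition measured at this position thus depends strongly on the group attached there, and an open chain is tolerated in place of the ring. Nothing available accounts for the size of this step.

The exchange alters ring, chain and terminal hydroxy together, and the compounds shown do not separate their contributions. A plain butylamino group, a terminal carboxylic acid or a longer hydroxyalkyl chain would each probe one part of it.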